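Pivaloyl in Place of Acetyl on the Lactone Ester

The source may hold more compounds than are shown below. What is called first, only, known or untested is meant among the compounds shown, and "the series" means these compounds.

Compound 2 `CC(=O)O[C@@H]1OC(=O)[C@@](C)(C(C)=O)[C@@H]1C` is measured in a functional assay on B16 cells (Mus musculus) for cytotoxicity, read by MTT assay (a lower number here means a stronger inhibitor, a higher number a weaker inhibitor), where compound 2 gives 14000 nM, the highest of the two numbers shown; the nearest is compound 1 `CC(=O)[C@@]1(C)C(=O)O[C@@H](OC(=O)C(C)(C)C)[C@H]1C`, which in this assay gives 2000 nM. Compound 3 `CC(=O)O[C@@H]1OC(=O)[C@@](O)(C(C)=O)[C@@H]1C` reaches only the assay limit, > 50000 nM. Among the measured compounds shown here, the single measured step, an at least 3.5-fold higher number from compound 2 to compound 3 (0.55 log units; beyond the scatter), concerns the ring carbon and not the ester, so it offers no direct guide. Compound 4 `CC(=O)[C@]1(C)C(=O)O[C@@H](OC(=O)C(C)(C)C)[C@H]1C` differs from compound 2 by tert-butyl in place of methyl on a carbonyl carbon. Compound 1 carries the same tert-butyl ester yet also differs from compound 2 at the quaternary ring carbon, so its lower number is only a loose pointer toward the larger ester being tolerated. Compound 4 is accordingly expected to give 4000 nM, between 1200 nM and 14000 nM, an expected step of a 3.5-fold lower number from compound 2 to compound 4 (0.54 log units; beyond the scatter).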

Compound 4, half-maximal inhibitory concentration: 10000 nM
Compound 4: the middle estimate sits 2.5-fold (0.40 log units) below what was measured, within the range that was stated.
By their numbers in this assay, from the lowest: compound 1; then compounds 4 and 2 (each within the scatter of the next). At a limit, above all of these: compound 3.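

In this assay, tert-butyl in place of methyl on a carbonyl carbon can now be read alone, and it gives a 1.4-fold lower number from compound 2 to compound 4 (0.15 log units; within the scatter), so this exchange separates the two compounds by no more than the scatter. The loose pointer from compound 1 therefore does not hold for the ester. The difference lies instead with the configuration at a saturated ring carbon, a 5.0-fold higher number from compound 1 to compound 4 (0.70 log units; beyond the scatter), and the cause can be traced to the drawn structures: the fact that compounds 1 and 4 differ only in the configuration as drawn

As far as these compounds go, whether a phenyl group or a longer chain on that carbonyl carbon would behave like tert-butyl remains open. So does whether the configuration gap would persist with methyl there.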